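Swapping Fluoro for Hydroxy: From Compound 1 to Compound 4

This account rests on a few compounds, and the source may have more. Where it says the series, first, only, none or still open, it means among the compounds named here.

Of the compounds shown here, three sharing one core have been tested in a functional assay on NCI-H460 cells (Homo sapiens) for inhibition, read by MTT assay, with a stated time of 72 h; on this read-out higher numbers stand for weaker inhibition and lower numbers for stronger inhibition. Compound 1 `COc1cc(NC(C)CCCNC(=O)Nc2ccc(F)cc2)c2ncccc2c1` gives 26000 nM in this assay, the highest of the three numbers. Compound 2 `COc1cc(NC(C)CCCNC(=O)Nc2cc(C(F)(F)F)cc(C(F)(F)F)c2)c2ncccc2c1` gives 8300 nM, a number lower by a margin beyond the usual scatter, while compound 3 `COc1cc(NC(C)CCCNC(=O)NNC(=O)Nc2cc(C(F)(F)F)cc(C(F)(F)F)c2)c2ncccc2c1` gives 18000 nM, which lies within the scatter of compound 1. Compound 4 `COc1cc(NC(C)CCCNC(=O)Nc2ccc(O)cc2)c2ncccc2c1` has not yet been measured in this assay. It differs from compound 1 in one place: hydroxy in place of fluoro on an aromatic carbon. The exchange sits on an aromatic carbon of a six-membered aromatic ring of carbon only, and it is a modest alteration of the structure. Among the measured compounds shown here, no measured pair shows this exchange, so there is no basis for expecting a step beyond the scatter in either direction. Compound 4 is therefore expected to give about 26000 nM in this assay, with a range from 9000 nM to 75000 nM. The step this estimate implies is no change at the digits printed from compound 1 to compound 4 (within the scatter), which is expected to stay inside the usual scatter.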

Compound 4, half-maximal inhibitory concentration: 34000 nM
Estimate against measurement, compound 4: 1.3-fold (0.12 log units) below, within the range that was stated.
By their numbers in this assay, from the lowest: compound 2; then compounds 3, 1 and 4 (each within the scatter of the next).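

In this assay, among the compounds shown here, hydroxy in place of fluoro on this aromatic carbon, para to a large group, gives a 1.3-fold higher number from compound 1 to compound 4 (0.12 log units; within the scatter) and so provides the first step in the set that can be read at a single position. It shows that this exchange, which brings in one hydrogen-bond donor and one hydrogen-bond acceptor where fluoro has none, leaves the number inside the usual scatter. No measurement given here accounts for this result.

From the compounds shown here alone, whether an amine, a carboxylic acid or a methoxy group at this position would also stay within the scatter remains open. Going by these compounds, it is also open whether hydroxy would give a similar step on the aromatic ring of compound 2, which carries two trifluoromethyl groups.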